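A few compounds are considered here, and "the series" means these few. Any claim that something is new, unique, unknown or untested is made for them only; others in the source may bear on it.

Compound 1 `CN(C)C(=O)c1cccnc1NCCCN1CCN(c2ccccc2O)CC1` was tested in a functional assay for antagonist activity at Alpha-1A adrenergic receptor (Oryctolagus cuniculus) (on this read-out lower numbers stand for tighter binding and higher numbers for weaker binding), where compound 1 gives 5.01 nM, the highest of the three numbers in hand. Compound 2 `CN(C)C(=O)c1cccnc1NCCCN1CCN(c2ccccc2OC(F)(F)F)CC1` gives 3.16 nM, and compound 3 `CN(C)C(=O)c1cccnc1NCCCN1CCN(c2ccccc2-c2ncco2)CC1` gives 0.316 nM. The step of a 1.6-fold lower number from compound 1 to compound 2 (0.20 log units; within the scatter) shows that altering the oxygen on the aromatic ring barely moves the number, whereas a 16-fold lower number from compound 1 to compound 3 (1.20 log units; beyond the scatter) and a 10-fold lower number from compound 2 to compound 3 (1.00 log units; beyond the scatter) show that replacing that oxygen-bearing group with 1,3-oxazol-2-yl lowers it strongly. Compound 4 `COc1cc(O)ccc1N1CCN(CCCNc2ncccc2C(=O)N(C)C)CC1` differs from compound 1 in that (4-hydroxy-2-methoxyphenyl in place of 2-hydroxyphenyl on an amine nitrogen in a ring). This change keeps a hydroxy and adds a methoxy, and most resembles the step of a 1.6-fold lower number from compound 1 to compound 2 (0.20 log units; within the scatter). Compound 4 is therefore expected to show a 1.2-fold higher number from compound 1 to compound 4 (0.08 log units; within the scatter). Compound 4 is estimated at 6 nM, with a range from 1.5 nM to 25 nM.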

Compound 4, dissociation constant: 12.6 nM
The estimate for compound 4 lay 2.1-fold (0.32 log units) below the measured number, within the range that was stated.
By their numbers in this assay, from the lowest: compound 3; then compounds 2 and 1 (each within the scatter of the next); then compound 4.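

Moving from 2-hydroxyphenyl to 4-hydroxy-2-methoxyphenyl on the amine nitrogen in the ring gives, in this assay, a 2.5-fold higher number from compound 1 to compound 4 (0.40 log units; beyond the scatter). This is the first change shown at this position that raises the number beyond the scatter, so changes here can weaken binding as well as strengthen it. No measurement available explains this rise. The compounds shown do not separate the added methoxy from the new location of the hydroxy, and 2-methoxyphenyl and 4-hydroxyphenyl on the same nitrogen would pull those two apart.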